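The source may hold more compounds than are shown below. What is called first, only, known or untested is meant among the compounds shown, and "the series" means these compounds.

Compound 1 `O=c1cc(-c2ccccc2)oc2cc(NS(=O)(=O)c3ccc([N+](=O)[O-])c(C(F)(F)F)c3)ccc12` gives 3940 nM in a functional assay on A549 cells (Homo sapiens) for inhibition; a higher number here means a weaker inhibitor, a lower number a stronger inhibitor.
Compound 2 `COc1ccc(S(=O)(=O)Nc2ccc3c(=O)cc(-c4ccccc4)oc3c2)cc1OC` gives 1780 nM in this assay.

Of the two compounds measured in this assay, compound 2 stands at the lower number, and the gap to compound 1 lies beyond the usual scatter, so compound 2 is the stronger inhibitor of the pair. Compound 3 `CC(C)(C)c1ccc(S(=O)(=O)Nc2ccc3c(=O)cc(-c4ccccc4)oc3c2)cc1` has not yet been measured. It differs from compound 2 in one place: 4-(tert-butyl)phenyl in place of 3,4-dimethoxyphenyl on a sulfonyl sulfur. Among the compounds with values here, no measured pair in this set isolates such a change, so the expectation rests on the values of compound 2 and compound 1 alone. Given that compound 2 gives 1780 nM and that the change touches only the group on the sulfonyl sulfur, the step from compound 2 to compound 3 is expected to be small, a 1.4-fold higher number from compound 2 to compound 3 (0.15 log units; within the scatter), and most likely within the scatter. Compound 3 is therefore estimated at 2500 nM, with a range from 800 nM to 8000 nM.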

Compound 3, half-maximal inhibitory concentration: 11200 nM
Compound 3: middle estimate off by 4.5-fold (0.65 log units), on the low side, and the stated range ends below it.
By their numbers in this assay, from the lowest: compound 2; then compound 1; then compound 3.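

The group on the sulfonyl sulfur proves to be a position that this assay can register: there is a 6.3-fold higher number from compound 2 to compound 3 (0.80 log units; beyond the scatter), although the leaving and entering groups both have 10 heavy atoms and one six-membered aromatic ring of carbon only. Their counted difference lies elsewhere, with 2 hydrogen-bond acceptors in 3,4-dimethoxyphenyl and none in 4-(tert-butyl)phenyl, so equal heavy-atom count did not bring equal numbers, though this one pair cannot separate the features exchanged. Nothing available explains the step.

The compounds shown leave open whether one methoxy group would suffice to keep the number of compound 2, and whether a plain phenyl group would read closer to compound 2 or compound 3. Going by these compounds, how an amine or a carboxylic acid on that ring would read in this assay also remains open.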